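The source may hold more compounds than are shown below. What is called first, only, known or untested is meant among the compounds shown, and "the series" means these compounds.

Series notes. The shared core of compound 1 `CC(C)N(Cc1cccc(OCCCCCC(=O)O)c1)C(=O)c1ccc(-c2cccc3ccccc23)cc1` carries a naphthalen-1-yl group on an aromatic carbon; in an ADME assay on BJ cells (Homo sapiens) for cytotoxicity, read by CellTiter-Glo and resazurin assay, with a stated time of 72 h (on this read-out lower numbers stand for an effect already at smaller amounts and higher numbers for an effect only at larger amounts of compound), compound 1 sits at a limit of the assay, < 1.3 nM. Compound 2 `CC(=O)c1cccc(-c2ccc(C(=O)N(Cc3cccc(OCCCCCC(=O)O)c3)C(C)C)cc2)c1` carries 3-acetylphenyl at that carbon. In this assay compound 2 also sits at a limit, > 26000 nM. Compound 3 `CCOc1cccc(-c2ccc(C(=O)N(Cc3cccc(OCCCCCC(=O)O)c3)C(C)C)cc2)c1` carries 3-ethoxyphenyl there. In this assay compound 3 stands at a limit as well, > 20800 nM, so only an edge of its range is known, and of the three values shown two are limits of this kind.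

Measured steps: an at least 20000-fold higher number from compound 1 to compound 2 (4.30 log units; beyond the scatter) and an at least 16000-fold higher number from compound 1 to compound 3 (4.20 log units; beyond the scatter); both large. The step that the two limits leave unreadable from compound 2 to compound 3 cannot be sized, since both ends are limits.

Compound 4 `COc1cc(F)cc(-c2ccc(C(=O)N(Cc3cccc(OCCCCCC(=O)O)c3)C(C)C)cc2)c1` differs from compound 3 by 3-fluoro-5-methoxyphenyl in place of 3-ethoxyphenyl on an aromatic carbon, in the place where the aromatic carbon sits para to a large group. Both compound 2 and compound 3, each with a substituted phenyl at this carbon, gave only a limit in this assay, so no step beyond the scatter is expected from compound 3 to compound 4, an at least 1.0-fold lower number from compound 3 to compound 4 (0.01 log units; that floor lies within the scatter). The expected value for compound 4 is 20000 nM, within 5000 nM to 60000 nM, most likely again reported as a limit.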

Compound 4, half-maximal effective concentration: > 26000 nM
Compound 4 gave a limit, no number (the forecaster's own chance of this, stated with the estimate: 70%); middle value at least 1.3-fold (0.11 log units) from the limit.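

In this assay a third substituted phenyl at the aromatic carbon para to a large group, here 3-fluoro-5-methoxyphenyl, again yields only a limit and not a number, and compound 4 shares that limit with compound 2: the limit of > 26000 nM in this assay, at which 2 of the 4 values shown sit. Measured against naphthalen-1-yl, the change gives an at least 20000-fold higher number from compound 1 to compound 4 (4.30 log units; beyond the scatter) and so extends the large gap seen with 3-acetylphenyl and 3-ethoxyphenyl to a phenyl ring bearing both fluoro and methoxy groups. The steps among compound 2, compound 3 and compound 4 cannot be read, since both ends of each are limits, and no order among these three groups can be stated.

The compounds shown leave open whether any group at this carbon would give a readable number between the limits of compound 1 and those of the substituted phenyl compounds. On these data alone, how naphthalen-2-yl, unsubstituted phenyl, or a phenyl carrying an amine or a carboxylic acid would stand in this read-out also remains open, as does how much of the gap depends on naphthalen-1-yl itself.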